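Swapping one aryl group at the stability limit

The source may hold more compounds than are shown below. What is called first, only, known or untested is meant among the compounds shown, and "the series" means these compounds.

In an ADME assay on microsomes from liver (Rattus norvegicus) for metabolic stability (a lower number here means that the compound disappears faster, a higher number that the compound lasts longer), compound 1 `FC(F)(F)c1ccc(NCCNc2ncc(-c3ncc[nH]3)c(-c3ccc(Cl)cc3Cl)n2)nc1` gives > 0.5 h as a limit and not a number. Compound 2 `Clc1ccc(-c2nc(NCCNc3ccccn3)ncc2-c2ncc[nH]2)c(Cl)c1` gives > 0.5 h as a limit too. Compound 3 `Nc1nc(NCCNc2ncc(-c3ncc[nH]3)c(-c3cc(F)ccc3F)n2)ccc1[N+](=O)[O-]` stands at > 0.5 h as a limit as well, so it has no exact number. Compound 4 `Nc1nc(NCCNc2ncc(-c3ncc[nH]3)c(-c3ccc(Br)cc3F)n2)ccc1[N+](=O)[O-]` differs from it in one place 4-bromo-2-fluorophenyl in place of 2,5-difluorophenyl on an aromatic carbon where 4-bromo-2-fluorophenyl replaces 2,5-difluorophenyl on an aromatic carbon. Within the data shown here, the one measured step that the two limits leave unreadable from compound 1 to compound 2 cannot be sized, and it concerns a different group. Among the measured compounds shown here, the only evidence is the limit of > 0.5 h in this assay, at which 3 of the 3 values shown sit, and it gives no direction. So no step beyond the scatter is expected, and the estimated step that the limit leaves unreadable from compound 3 to compound 4 stays small. Compound 4 is estimated at 0.7 h with a range of 0.3 h to 1.5 h in this assay once measured.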

Compound 4, half-life: > 0.5 h
Compound 4: a limit, no number; the forecaster's own chance of this, stated with the estimate: 70%; the middle value is on the limit's open side.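

In this assay, compound 3 and compound 4 both give limits rather than numbers, so the step between them cannot be read. The compounds shown leave open the actual half-life of each one, and whether swapping 2,5-difluorophenyl for 4-bromo-2-fluorophenyl changes it.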